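Replacing Amino with Hydroxy in a Small Compound Set

The source may hold more compounds than are shown below. What is called first, only, known or untested is meant among the compounds shown, and "the series" means these compounds.

Among the compounds with values here, only two compounds have so far been measured in a physicochemical assay for lipophilicity, read by HPLC; on this read-out higher numbers stand for higher lipophilicity and lower numbers for lower lipophilicity. Compound 2 (`Cc1ccc(CNC(=O)C(CCN)N(C)CCC=C(c2sccc2C)c2sccc2C)cc1`) gives 6.61, the higher of the two numbers. Compound 1 (`Cc1ccsc1C(=CCCN(C)C(CCO)C(=O)NCc1ccccc1Cl)c1sccc1C`) gives 6.23, which lies lower by more than the usual scatter of repeated measurements.

The next compound to be measured, compound 3 (`Cc1ccc(CNC(=O)C(CCO)N(C)CCC=C(c2sccc2C)c2sccc2C)cc1`), departs from compound 2 by a single change: hydroxy in place of amino on a saturated chain carbon, three bonds along the chain from an amine nitrogen and a carbonyl carbon. Put simply, hydroxy stands in place of amino on a saturated chain carbon, three bonds along the chain from an amine nitrogen and a carbonyl carbon.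

Within the data shown here, no pair of measured compounds differs in just one place, so no measured step can serve as a guide. Among the measured compounds shown here, the only other anchor is compound 1, itself a hydroxy compound, at 6.23. On that thin evidence, the expected change in this assay is small and slightly downward, with nothing expected beyond the scatter. The estimated step is a number 0.26 log units lower from compound 2 to compound 3 (within the scatter). For compound 3 the expected value is 6.35, with an estimated range from 5.95 to 6.75.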

Compound 3, partition coefficient: 6.2
Compound 3: middle estimate off by 0.15 log units, on the high side; measured number inside the range.
By their numbers in this assay, from the lowest: compounds 3 and 1 (each within the scatter of the next); then compound 2.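

In this assay, within the data shown here, hydroxy in place of amino on a saturated chain carbon, three bonds along the chain from an amine nitrogen and a carbonyl carbon, gives a number 0.41 log units lower from compound 2 to compound 3 (beyond the scatter), the first measured step at this position, and it shows that this one exchange moves the read-out even though the counts of hydrogen-bond donors and acceptors stay the same. With hydroxy held in place, 4-methylphenyl in place of 2-chlorophenyl on a saturated chain carbon bound to an amide-type nitrogen gives a number 0.03 log units lower from compound 1 to compound 3 (within the scatter), so in this pair the aryl exchange leaves no reading that can be told apart. No evidence bearing on the cause of either step is at hand.

Each of these changes rests on a single pair, so the compounds shown leave open whether the amino to hydroxy step keeps its size with 2-chlorophenyl in place of 4-methylphenyl, and whether the aryl exchange stays this small with amino on the chain. They also leave open how a carboxylic acid, a methoxy group or a longer chain would read at the same position.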